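Two ester tails on two cores in a cytotoxicity assay

The compounds below may be only part of what the source reports. "The series", "measured", "known", "first", "only" and "open" are said of these compounds alone.

Of the compounds shown here, three have been measured in a functional assay on HeLa cells (Homo sapiens) for cytotoxicity, read by MTT assay, with a stated time of 3 days; a higher number here means a weaker inhibitor, a lower number a stronger inhibitor. Compound 1 `CCC(C)COC(=O)Nc1nc(=O)n([C@@H]2O[C@H](C)[C@H]3OC(=O)O[C@H]32)cc1F` gives 180 ug/mL, and compound 3 `CC(C)CCOC(=O)Nc1nc(=O)n([C@@H]2O[C@H](C)[C@H]3OC(=O)O[C@H]32)cc1F` gives 130 ug/mL. The change from compound 1 to compound 3 is isobutyl in place of sec-butyl on a saturated chain carbon bound to an oxygen next to a carbonyl group, and it made a step of a 1.4-fold lower number from compound 1 to compound 3 (0.14 log units; within the scatter). Compound 2 `CCC(C)COC(=O)Nc1nc(=O)n([C@@H]2O[C@H](C)[C@@H](O)[C@H]2O)cc1F` carries a different core; how its core differs from the core of compound 1 is not broken down here. In this assay compound 2 gives 90 ug/mL. Compound 4 `CC(C)CCOC(=O)Nc1nc(=O)n([C@@H]2O[C@H](C)[C@@H](O)[C@H]2O)cc1F` has not yet been measured. It stands to compound 2 as compound 3 stands to compound 1: the change is isobutyl in place of sec-butyl on a saturated chain carbon bound to an oxygen next to a carbonyl group, the same change at the same place. Because the earlier step was a 1.4-fold lower number from compound 1 to compound 3 (0.14 log units; within the scatter), a similarly small step of a 1.2-fold lower number from compound 2 to compound 4 (0.08 log units; within the scatter) is expected. This expectation rests on a single earlier pair on a different core, so it is held loosely. Compound 4 is expected to give about 75 ug/mL, with most repeats likely to fall between 35 ug/mL and 160 ug/mL.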

Compound 4, half-maximal inhibitory concentration: 90 ug/mL
Estimate against measurement, compound 4: 1.2-fold (0.08 log units) below; low and high end bracket the measured number.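

In this assay, putting isobutyl in place of sec-butyl on the second core gave no change at the digits printed from compound 2 to compound 4 (within the scatter), so the swap leaves no readable mark there. Set beside the earlier step on the core of compound 1, the new step tells the same story, and the two steps do not differ beyond what repeat measurements would produce: the same change on two cores in this assay, a 1.4-fold lower number (0.14 log units; within the scatter) from compound 1 to compound 3 and no change at the digits printed (within the scatter) from compound 2 to compound 4, 1.4-fold (0.14 log units) apart, within the scatter of two such steps This shows that, across these two cores, the swap behaves alike and stays too small to read, but it does not show that sec-butyl and isobutyl are truly equivalent, since a small real effect could hide within the scatter, and two pairs say nothing about any third core.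

The compounds shown leave open whether a tail that differs more from these two, such as a longer chain or a benzyl group, would move the number by a readable amount. They also leave open how a tail carrying an amine or a carboxylic acid would behave on either core.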